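Shortening a hydroxypropyl chain to methoxymethyl: expected cytotoxicity

This account rests on a few compounds, and the source may have more. Where it says the series, first, only, none or still open, it means among the compounds named here.

Compound 1, `CCCN(c1ccnc(Nc2ccc(C#N)cc2)n1)c1c(F)cc(-c2ccc(C#N)cc2)cc1F`: 212000 nM
Compound 2, `N#Cc1ccc(Nc2nccc(N(CCCO)c3c(F)cc(-c4ccc(C#N)cc4)cc3F)n2)cc1`: 68000 nM

Within the data shown here, in an ADME assay on MT4 cells (Homo sapiens) for cytotoxicity, read by MTT assay, with a stated time of 5 days (on this read-out lower numbers stand for higher toxicity in this test and higher numbers for lower toxicity in this test), compound 2 holds the lower of the two numbers known so far; the single measured step, a 3.1-fold lower number from compound 1 to compound 2 (0.49 log units; beyond the scatter), separates it from the other compound, so compound 2 is the more toxic of the pair in this assay.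

Compound 3, `COCN(c1ccnc(Nc2ccc(C#N)cc2)n1)c1c(F)cc(-c2ccc(C#N)cc2)cc1F`, has not been measured. It differs from compound 2 by methoxy in place of 2-hydroxyethyl on a saturated chain carbon bound to a nitrogen on an aromatic ring.

Among the measured compounds shown here, the only measured step that bears on this change is a 3.1-fold lower number from compound 1 to compound 2 (0.49 log units; beyond the scatter), in which a hydroxy group arriving on a chain of this kind lowered the number beyond the scatter. Compound 3 gives up that hydroxy donor, keeping one acceptor on a shorter chain, so the number is expected to move part of the way back toward that of compound 1. The step expected here is a 2.2-fold higher number from compound 2 to compound 3 (0.34 log units; beyond the scatter). For compound 3 the estimate in this assay is 150000 nM, with a range from 60000 nM to 320000 nM.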

Compound 3, half-maximal cytotoxic concentration: 238000 nM
For compound 3 the middle estimate is 1.6-fold (0.20 log units) below the measured one, and the stated range covers the measured number.
By their numbers in this assay, from the lowest: compound 2; then compounds 1 and 3 (each within the scatter of the next).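

In this assay, putting methoxy in place of 2-hydroxyethyl gives a 3.5-fold higher number from compound 2 to compound 3 (0.54 log units; beyond the scatter) and so undoes the drop seen with the hydroxy group, while methoxy in place of ethyl gives a 1.1-fold higher number from compound 1 to compound 3 (0.05 log units; within the scatter) and leaves those two compounds indistinguishable. An oxygen on this chain therefore does not by itself go with the lower number: among these three compounds, only the chain ending in hydroxy, the one with a hydrogen-bond donor, stands apart. No measurement here explains this difference.

Because this change alters both the chain length and its end group, the compounds shown cannot separate the two, and a methoxypropyl chain would be the direct test. As far as these compounds go, whether an amine at the chain end would match the hydroxy also remains open.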